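The source may hold more compounds than are shown below. What is called first, only, known or untested is meant among the compounds shown, and "the series" means these compounds.

Measured compounds:
compound 1 `CCOC(=O)C1=Cc2ccccc2OC1(OCc1cn(CC(=O)NC2CCCCC2)nn1)C(F)(F)F`: 12100 nM
compound 2 `CCCCCCCCn1cc(COC2(C(F)(F)F)Oc3ccccc3C=C2C(=O)OCC)nn1`: > 150000 nM
compound 3 `O=C(O)C1=Cc2ccccc2OC1(OCc1cc(-c2ccc(F)cc2F)no1)C(F)(F)F`: > 150000 nM

In a functional assay on MCF7 cells (Homo sapiens) for inhibition, read by MTT assay, with a stated time of 24 h (on this read-out higher numbers stand for weaker inhibition and lower numbers for stronger inhibition), compound 2 gives only a limit, > 150000 nM. Compound 3 likewise sits at a limit, > 150000 nM. Compound 2 therefore stands at the limit of > 150000 nM in this assay, at which 2 of the 3 values shown sit. For the measured compounds named here, compound 1 is the one compound with a number, 12100 nM. Going by the values given here, the single measured step, an at least 12-fold higher number from compound 1 to compound 2 (1.09 log units; beyond the scatter), is large and runs toward weaker inhibition. Compound 4 `CCOC(=O)C1=Cc2ccccc2OC1(OCc1cn(-c2ccc(F)c(Cl)c2)nn1)C(F)(F)F` differs from compound 2 by 3-chloro-4-fluorophenyl in place of octyl on an aromatic nitrogen. Among the compounds with values here, no measured step swaps a chain for an aromatic ring on this nitrogen; the step of an at least 12-fold higher number from compound 1 to compound 2 (1.09 log units; beyond the scatter) only shows that the group there can shift the read-out strongly. Compound 4 is expected to move back toward stronger inhibition by an at least 3.0-fold lower number from compound 2 to compound 4 (0.47 log units; beyond the scatter), with wide uncertainty. The estimate for compound 4 is 50000 nM, between 8000 nM and 150000 nM.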

Compound 4, half-maximal inhibitory concentration: 25300 nM
Beside the measured number, compound 4's estimate is 2.0-fold (0.30 log units) above it; the measured number falls inside the stated range.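

Putting 3-chloro-4-fluorophenyl in place of octyl on this aromatic nitrogen brings the read-out back into the measurable range, with an at least 5.9-fold lower number from compound 2 to compound 4 (0.77 log units; beyond the scatter). The aryl group still falls modestly short of the amide-bearing side chain of compound 1, with a 2.1-fold higher number from compound 1 to compound 4 (0.32 log units; beyond the scatter). The first step gives only a minimum size, since compound 2 sits at a limit: the limit of > 150000 nM in this assay, at which 2 of the 4 values shown sit.

The compounds shown cannot separate the effect of the aromatic ring itself from that of its chlorine and fluorine. Also open, on these data alone, is how plain phenyl, butyl or a chain ending in an amine would behave on this nitrogen.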